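The source may report more compounds than this note shows. Statements on the series, on what has been measured and on what is new or still open speak of the compounds shown alone.

Of the compounds shown here, three of one series have been measured in a functional assay on IGROV-1 cells (Homo sapiens) for inhibition, read by sulforhodamine B assay, with a stated time of 48 h, tested at 1 uM; a lower number here means a stronger effect, a higher number a weaker effect of the compound at the concentration tested. Compound 1 `O=C(Nc1cccc(-n2cc(-c3ccncc3)c(-c3cc(O)cc(Cl)c3)n2)c1)Nc1ccc(Cl)c(C(F)(F)F)c1` gives 113%. Compound 2 `COc1cc(Cl)cc(-c2nn(-c3cccc(NC(=O)Nc4ccc(Cl)c(C(F)(F)F)c4)c3)cc2-c2ccncc2)c1` gives 87%, and compound 3 `COc1cc(Cl)cc(-c2nn(-c3cccc(NC(=O)Nc4cc(C(F)(F)F)cc(C(F)(F)F)c4)c3)cc2-c2ccncc2)c1` gives 33%. Among these three numbers compound 2 stands second highest: the step of a number 26 percentage points lower from compound 1 to compound 2 (beyond the scatter) sets it beyond the scatter from compound 1, and compound 3 lies further away still, beyond the scatter on the lower side.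

Compound 4 `COc1cc(Cl)cc(-c2nn(-c3cccc(NC(=O)c4cccc(C(F)(F)F)c4)c3)cc2-c2ccncc2)c1` has not yet been measured. It differs from compound 2 in one place: 3-(trifluoromethyl)phenyl in place of (4-chloro-3-(trifluoromethyl)phenyl)amino on a carbonyl carbon.

Among the compounds with values here, no measured step bears directly on this change. Within the data shown here, the only step on record, a number 26 percentage points lower from compound 1 to compound 2 (beyond the scatter), concerns the methyl on the oxygen of the other aromatic ring, which compound 4 keeps unchanged. Among the measured compounds shown here, the gap between compound 2 and compound 3 shows that the group on the carbonyl carbon can move the number a long way, but that pair changes a different part of that group and no step is given for it. The expectation for compound 4 therefore rests on little: the loss of the amino link and the chlorine is expected to leave the number near that of compound 2 or somewhat higher, a step of a number 8 percentage points higher from compound 2 to compound 4 (within the scatter). Compound 4 is accordingly estimated at 95%, within a range from 60% to 125%.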

Compound 4, a percentage reported as activity, at one concentration (the size of the read-out at that concentration, not a potency): 94%
Beside the measured number, compound 4's estimate is 1 percentage points above it; low and high end bracket the measured number.
By their numbers in this assay, from the lowest: compound 3; then compounds 2 and 4 (each within the scatter of the next); then compound 1.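

In this assay, putting 3-(trifluoromethyl)phenyl in place of (4-chloro-3-(trifluoromethyl)phenyl)amino on the carbonyl carbon gives a number 7 percentage points higher from compound 2 to compound 4 (within the scatter). Within the data shown here, this is the first direct reading of a change at this position, and it shows that the amino link, with its hydrogen-bond donor, and the chlorine can leave together without a difference that this read-out can distinguish at the concentration tested. No measurement shown here offers an explanation for this outcome.

Because the two groups leave in a single change, the compounds shown do not separate the contribution of the amino link from that of the chlorine, and they do not show whether the same exchange would be equally silent with the group on the carbonyl carbon of compound 3. Also open is how the number would respond if a morpholine, a piperidine or a short alkyl chain stood on the carbonyl carbon in place of the aromatic ring, since every compound shown carries an aromatic ring on that side.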